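A few compounds are considered here, and "the series" means these few. Any claim that something is new, unique, unknown or untested is made for them only; others in the source may bear on it.

Of the compounds shown here, three sharing one core have been tested in a toxicity assay on HT-29 cells (Homo sapiens) for cytotoxicity; a higher number here means that more compound is tolerated, a lower number that less compound is tolerated. Compound 1 `CN1C(=S)[C@@H](NC(=O)c2n[nH]c(Cc3ccccc3)n2)COc2ccccc21`, with a hydrogen on the aromatic nitrogen, gives > 50000 nM, which is a limit and not a number. Compound 2 `CCCCn1nc(C(=O)N[C@H]2COc3ccccc3N(C)C2=S)nc1Cc1ccccc1`, with a butyl on that nitrogen, gives > 100000 nM, also a limit. Compound 3 `CC(C)Cn1nc(C(=O)N[C@H]2COc3ccccc3N(C)C2=S)nc1Cc1ccccc1`, with an isobutyl there, gives > 100000 nM, again a limit. Compound 3 therefore has no exact value and stands at the limit of > 100000 nM in this assay, at which 2 of the 3 values shown sit.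

Compound 4 `CC(C)CCn1nc(C(=O)N[C@H]2COc3ccccc3N(C)C2=S)nc1Cc1ccccc1` has not yet been measured. It differs from compound 3 by one change: isobutyl in place of isopropyl on a saturated chain carbon bound to an aromatic nitrogen. Put another way, the change is isobutyl to isopentyl.

The closest measured change in this chain is a step that the two limits leave unreadable from compound 2 to compound 3. Replacing the hydrogen gave a step that the two limits leave unreadable from compound 1 to compound 2 and a step that the two limits leave unreadable from compound 1 to compound 3. None of these steps has a readable size, so they point in no direction. They do show that the butyl and isobutyl compounds both rest at the limit of > 100000 nM in this assay, at which 2 of the 3 values shown sit. The step expected in this assay is therefore no larger than the usual scatter, an estimated a number no higher from compound 3 to compound 4 (the limit leaves the size open). Compound 4 will most likely be reported as a limit again. Compound 4 is estimated at 100000 nM, with an expected range from 50000 nM to 200000 nM.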

Compound 4, half-maximal cytotoxic concentration: > 100000 nM
Compound 4: only a limit was reported; the forecaster's own chance of this, stated with the estimate: 90%; the middle value sits exactly at the limit.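

In this assay, for the compounds shown here, compound 4 gives > 100000 nM, again a limit and not a number, so no step from compound 1, compound 2 or compound 3 to compound 4 can be read. The compounds shown leave open what concentration the cells would fail to tolerate, and whether the group on the aromatic nitrogen alters it.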